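Pyrimidine in place of a substituted phenyl on the sulfonamide

This account rests on a few compounds, and the source may have more. Where it says the series, first, only, none or still open, it means among the compounds named here.

For the measured compounds named here, compound 3 `COc1ccc(F)c(-c2ccc(S(=O)(=O)Nc3cc(N4C[C@@H](C)N[C@@H](C)C4)ccc3OC)cc2)c1` holds the lowest number of the three measured so far in a functional assay for agonist activity at growth hormone secretagogue receptor type 1 (Homo sapiens), read by FLIPR; on this read-out higher numbers stand for an effect only at larger amounts of compound and lower numbers for an effect already at smaller amounts: in that assay compound 3 gives 0.398 nM. Compound 1 `COc1ccc(NS(=O)(=O)c2ccc(-c3ccccn3)s2)cc1N1C[C@@H](C)N[C@@H](C)C1` is the nearest to it, and in this assay compound 1 gives 15.9 nM, a gap beyond the usual scatter. Compound 2 `C[C@@H]1CN(c2ccc(F)c(NS(=O)(=O)c3ccc(-c4ccccn4)s3)c2)C[C@H](C)N1` lies furthest away, and in this assay compound 2 gives 100 nM, also beyond the scatter. Compounds 1 and 2 differ from compound 3 in more than one place, so their values can only be set side by side, not read as single steps.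

Compound 4 `COc1ccc(N2C[C@@H](C)N[C@@H](C)C2)cc1NS(=O)(=O)c1ccc(-c2cncnc2)cc1` differs from compound 3 in one place: pyrimidin-5-yl in place of 2-fluoro-5-methoxyphenyl on an aromatic carbon. Going by the values given here, no measured pair shows this change on its own, so its size is not known from the data. Compound 3 carries the lowest number with the substituted phenyl in place, and the step of a 13-fold higher number from compound 3 to compound 4 (1.10 log units; beyond the scatter) is expected to lead toward higher numbers, beyond the scatter. Compound 4 is therefore estimated at 5 nM, with a range from 1 nM to 30 nM.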

Compound 4, half-maximal effective concentration: 316 nM
For compound 4 the middle estimate is 63-fold (1.80 log units) below the measured one; measured number above the stated range.
By their numbers in this assay, from the lowest: compound 3; then compound 1; then compound 2; then compound 4.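

Replacing 2-fluoro-5-methoxyphenyl with pyrimidin-5-yl gives a 790-fold higher number from compound 3 to compound 4 (2.90 log units; beyond the scatter) in this assay, the first step among these compounds that can be read at a single place, and it shows that the group on this aromatic carbon, para to a large group, strongly shapes the result. For the compounds shown here, the one change alters several things together: a ring of carbon only gives way to a ring with 2 hetero atoms, the group shrinks from 9 heavy atoms to 6, and the fluorine and methoxy both leave. No measurement shown here accounts for the size of this step.

Which of these alterations carries the step stays open. A plain phenyl, a phenyl bearing only a methoxy or only a fluorine, or a pyridin-3-yl ring at this place would begin to separate them.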